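Restoring a (Methylsulfanyl)methyl Group on a Cyclodepsipeptide

A few compounds are considered here, and "the series" means these few. Any claim that something is new, unique, unknown or untested is made for them only; others in the source may bear on it.

Two compounds sharing one macrocyclic core were tested in a functional assay on K562 cells (Homo sapiens) for cytotoxicity, read by CellTiter-Blue, with a stated time of 72 h; a higher number here means a weaker inhibitor, a lower number a stronger inhibitor. Compound 1, `C/C=C(\C)[C@H]1OC(=O)[C@@H](C)NC(=O)[C@H]([C@@H](C)CC)NC(=O)CN(C)C(=O)[C@@H](Cc2ccccc2)N(C)C(=O)[C@H](C)NC(=O)[C@@H](CC(C)C)OC(=O)/C(C)=C/C[C@H](OCSC)[C@@H]1C`, gives 0.0063 nM. Compound 2, `C/C=C(\C)[C@H]1OC(=O)[C@@H](C)NC(=O)[C@H]([C@@H](C)CC)NC(=O)CN(C)C(=O)[C@@H](Cc2ccccc2)N(C)C(=O)[C@@H](C)NC(=O)[C@@H](CC(C)C)OC(=O)/C(C)=C/C[C@H](O)[C@@H]1C`, gives 584 nM, the higher of the two numbers; the gap between compound 2 and compound 1 lies far beyond the scatter. Compound 3, `C/C=C(\C)[C@H]1OC(=O)[C@@H](C)NC(=O)[C@H]([C@@H](C)CC)NC(=O)CN(C)C(=O)[C@@H](Cc2ccccc2)N(C)C(=O)[C@@H](C)NC(=O)[C@@H](CC(C)C)OC(=O)/C(C)=C/C[C@H](OCSC)[C@@H]1C`, has not been measured. It differs from compound 2 by (methylsulfanyl)methyl in place of hydrogen on an oxygen on a saturated carbon. For the measured compounds named here, no step between measured compounds describes this exact change, yet compound 3 is the same structure as compound 1, so a large downward step is expected, matching the difference between compound 2 and compound 1. The step from compound 2 to compound 3 is therefore estimated as a 93000-fold lower number from compound 2 to compound 3 (4.97 log units; beyond the scatter). Compound 3 is expected to give about 0.0063 nM, within a range of 0.002 nM to 0.02 nM in this assay.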

Compound 3, half-maximal inhibitory concentration: 1190 nM
Compound 3: the middle estimate sits 190000-fold (5.28 log units) below what was measured; measured number outside the range, above it.
By their numbers in this assay, from the lowest: compound 1; then compound 2; then compound 3.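

In this assay, (methylsulfanyl)methyl in place of hydrogen on an oxygen on a saturated carbon gives only a 2.0-fold higher number from compound 2 to compound 3 (0.31 log units; beyond the scatter), so with the configuration drawn in these two compounds the change raises the number modestly instead of lowering it. The far larger step, a 190000-fold higher number from compound 1 to compound 3 (5.28 log units; beyond the scatter), comes with a single stereocentre at a saturated ring carbon, drawn S in the first and R in the second: the fact that compounds 1 and 3 differ only in the configuration as drawn Compound 1 and compound 2 differ in both places at once, so their two values alone could not separate the group from the stereocentre.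

The compounds shown leave open how the hydroxy form behaves with the stereocentre drawn as in compound 1. They also leave open whether a methoxy group, an amine or a longer thioether chain on that oxygen would give a number nearer to that of compound 2.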